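A few compounds are considered here, and "the series" means these few. Any claim that something is new, unique, unknown or untested is made for them only; others in the source may bear on it.

Within the data shown here, the two compounds measured so far share one core and differ only at the ring nitrogen of that core. Compound 1 (`COc1ccc(-c2cc(=O)c3c(OC)cc(OC)cc3[nH]2)cc1`) carries a hydrogen there; in a functional assay on KOPN-8 cells (Homo sapiens) for antiproliferative activity, with a stated time of 72 h (on this read-out higher numbers stand for an effect only at larger amounts of compound and lower numbers for an effect already at smaller amounts), compound 1 gives > 31100 nM, which is a limit of the assay rather than a number. Compound 2 (`COc1ccc(-c2cc(=O)c3c(OC)cc(OC)cc3n2S(=O)(=O)c2cc(Cl)cc(Cl)c2O)cc1`) bears a sulfonyl group on that nitrogen; in this assay compound 2 gives > 37900 nM, again a limit and not a number. Among the measured compounds shown here, compound 2 therefore stands at a limit, and the one further value shown is likewise a limit (the limit of > 31100 nM in this assay, at which 1 of the 2 values shown sits, (the limit of > 37900 nM in this assay, at which 1 of the 2 values shown sits)), so no step between measured compounds can be sized.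

Compound 3 (`COc1ccc(-c2cc(=O)c3c(OC)cc(OC)cc3n2S(=O)(=O)c2ccc(OC)cc2)cc1`) keeps the sulfonyl on the ring nitrogen and changes only the group on the sulfonyl sulfur: 4-methoxyphenyl in place of 3,5-dichloro-2-hydroxyphenyl on a sulfonyl sulfur. With both measured compounds sitting at limits, the account expects no step beyond the scatter from compound 2 to compound 3, that is, an expected step that the limit leaves unreadable from compound 2 to compound 3. Compound 3 is accordingly estimated at 40000 nM, with a range of 15000 nM to 120000 nM, most likely again reported only as a limit.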

Compound 3, half-maximal effective concentration: > 82700 nM
Compound 3 gave a limit, no number; the forecaster's own chance of this, stated with the estimate: 75%; at least 2.0-fold (0.31 log units) between middle value and limit.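

In this assay, compound 1, compound 2 and compound 3 all stand at limits of the assay and not at numbers, so neither the step from compound 2 to compound 3 nor the step from compound 1 to compound 3 can be read. The compounds shown leave open whether any group on the aromatic nitrogen or on the sulfonyl sulfur gives a measurable effect in this assay.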